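The source may report more compounds than this note shows. Statements on the series, on what has been measured and on what is new or still open speak of the compounds shown alone.

Compound 2 `C/C(=N\O)c1ccc(NC(=O)CSc2nnc(-c3ccccc3)n2-c2ccccc2)cc1` stands lowest of the two numbers in a functional assay on the whole organism (strain albino) for inhibition, with Rattus norvegicus as the target, read by paw edema, with stated times of 30 min and 4 h, at a dose of 0.28 mmol/kg by the oral route (on this read-out lower numbers stand for less inhibition and higher numbers for more inhibition at the one dose given (going by the name of the read-out)), where compound 2 gives 67%. Its nearest neighbour is compound 1 `COc1cc(-c2nnc(SCC(=O)Nc3ccc(/C(C)=N/O)cc3)n2-c2ccccc2)cc(OC)c1OC`, which in this assay gives 75%; the step of a number 8 percentage points lower from compound 1 to compound 2 (within the scatter) came with phenyl in place of 3,4,5-trimethoxyphenyl on an aromatic carbon and lies within the scatter. Compound 3 `COc1ccc(-c2nnc(SCC(=O)Nc3ccc(/C(C)=N/O)cc3)n2-c2ccccc2)cc1` differs from compound 2 by methoxy in place of hydrogen on an aromatic carbon. Going by the values given here, the only step bearing on a change of methoxy count on that ring is the one just given, and it stayed within the scatter, so no step beyond the scatter is expected for a number 3 percentage points higher from compound 2 to compound 3 (within the scatter). Compound 3 is estimated at 70%, with a range of 58% to 82%.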

Compound 3, a percentage reported as inhibition, in the whole organism at one dose (the size of the read-out at that dose, not a potency): 69%
Estimate against measurement, compound 3: 1 percentage points above, and the stated range covers the measured number.
By their numbers in this assay, from the lowest: compounds 2, 3 and 1 (each within the scatter of the next).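

In this assay, the change from phenyl to 4-methoxyphenyl gives a number 2 percentage points higher from compound 2 to compound 3 (within the scatter), and 4-methoxyphenyl in place of 3,4,5-trimethoxyphenyl gives a number 6 percentage points lower from compound 1 to compound 3 (within the scatter). The single methoxy para to a large group therefore adds an intermediate member, and none of the three ring patterns separates from the others at this one dose. No measured property bears on these numbers.

Going by these compounds, whether an amine, a chlorine or a carboxylic acid on this ring would give a step beyond the scatter remains open. On these data alone, the effect of replacing the oxime on the other ring also remains open.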